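A few compounds are considered here, and "the series" means these few. Any claim that something is new, unique, unknown or untested is made for them only; others in the source may bear on it.

Measured so far, in an ADME assay on HEL cells (Homo sapiens) for cytotoxicity; a lower number here means that less compound is tolerated, a higher number that more compound is tolerated:

Compound 1, `C/C(=N\NC(=O)COc1cccc2ccccc12)c1ccccc1`, gives 20 ug/mL.
Compound 2, `C/C(=N\NC(=O)COc1cccc2ccccc12)c1ccccc1Br`, gives 20 ug/mL.
Compound 3, `O=C(COc1cccc2ccccc12)N/N=C/c1ccccc1`, gives 100 ug/mL.

Compound 1 and compound 2 share a core; compound 2 differs by bromo in place of hydrogen on an aromatic carbon, and this step, no change at the digits printed from compound 1 to compound 2 (within the scatter), left the result where it was. Compound 3 has a different core, and how the two cores differ is not broken down here; its value stands well apart from compound 1 and compound 2, as the number shows.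

Compound 4, `O=C(COc1cccc2ccccc12)N/N=C/c1cccc(Br)c1`, is not yet measured. It differs from compound 3 by bromo in place of hydrogen on an aromatic carbon. Among the compounds with values here, this is the same kind of change as the one from compound 1 to compound 2, though not the same: there the bromo sits ortho to a large group, here it sits meta to a large group.

Within the data shown here, the only measured instance of this kind of change is no change at the digits printed from compound 1 to compound 2 (within the scatter), so a step of about the same size, no change at the digits printed from compound 3 to compound 4 (within the scatter), is expected from compound 3 to compound 4. Compound 4 is therefore estimated at 100 ug/mL, between 50 ug/mL and 200 ug/mL.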

Compound 4, minimum cytotoxic concentration in the HEL assay: 100 ug/mL
Compound 4: middle estimate and measured number agree at the digits printed; the measured number falls inside the stated range.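

In the HEL assay the new step reads no change at the digits printed from compound 3 to compound 4 (within the scatter), and it matches the earlier step on the other core, so on these two cores the bromo change behaves alike: the same change on two cores in the HEL assay, no change at the digits printed (within the scatter) from compound 1 to compound 2 and no change at the digits printed (within the scatter) from compound 3 to compound 4, 1.0-fold (0.00 log units) apart, within the scatter of two such steps The compounds are not the same on every read-out, though: in a physicochemical assay for lipophilicity, measured as octanol-water partition (on this read-out lower numbers stand for lower lipophilicity and higher numbers for higher lipophilicity), compound 3 gives 4.02 and compound 4 gives 4.81, a gap beyond the scatter, even though the cell read-out stays put. This agreement rests on just two pairs, with the bromo at a different place in each, so it does not show that the change would carry over to any further core or ring position.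

The compounds shown leave open whether a group other than bromo, such as an amine or a carboxylic acid, would also leave the cell read-out unchanged on these cores. They also leave open which part of the difference between the two cores goes with the wider gap in the cell read-out.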